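The source may hold more compounds than are shown below. What is called first, only, known or untested is meant among the compounds shown, and "the series" means these compounds.

Of the compounds shown here, two have so far been measured in an assay on cells for agonist activity at probable G-protein coupled receptor 34 (Mus musculus), with a stated time of 1 h; a higher number here means a larger maximal response, a lower number a smaller maximal response. Compound 1 `N[C@@H](COP(=O)(O)OCCCOC(=O)CCc1ccccc1OCCCCCCOc1ccccc1)C(=O)O` gives 20.7% in this assay. Compound 2 `Cc1ccc(Oc2cccc(COc3ccccc3CCC(=O)OCCCOP(=O)(O)OC[C@H](N)C(=O)O)c2)cc1` gives 18.2% in this assay. Compound 2 stands lowest of the two numbers, but its distance to compound 1 lies within the scatter, so the two cannot be told apart. Compound 3 `N#Cc1ccc(Oc2cccc(COc3ccccc3CCC(=O)OCCCOP(=O)(O)OC[C@H](N)C(=O)O)c2)cc1` has not yet been measured. It differs from compound 2 in one place: cyano in place of methyl on an aromatic carbon. Going by the values given here, no step between two measured compounds is available that would show how such a change has acted before. Among the compounds with values here, the only guide is that compound 1 and compound 2, which differ from each other far more than compound 2 and compound 3 do, lie close together. For compound 3 a step of a number 0.2 percentage points lower from compound 2 to compound 3 (within the scatter) is expected, nothing beyond the scatter. The estimate for compound 3 in this assay is 18%, with a range from 8% to 30%.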

Compound 3, largest response reached (Emax), in percent of the reference or control that the assay uses: 18.3%
Estimate against measurement, compound 3: 0.3 percentage points below, and the stated range covers the measured number.
By their numbers in this assay, from the lowest: compounds 2, 3 and 1 (each within the scatter of the next).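

In this assay, going by these compounds alone, the first comparison of two compounds that differ in one place shows that cyano in place of methyl on an aromatic carbon, para to a large group, gives a number 0.1 percentage points higher from compound 2 to compound 3 (within the scatter) and so leaves the maximal response unresolved between the two. At this position, therefore, 4-methylphenoxy and 4-cyanophenoxy cannot be told apart, even though the cyano group adds a hydrogen-bond acceptor and a triple bond that the methyl group lacks. No supporting measurement bears on this result.

The compounds shown leave open whether this position stays as indifferent with a primary amine, a carboxylic acid or a longer alkyl chain in the same place. They also leave open whether the same exchange would give a similar result on another core, such as that of compound 1.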